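Chloro-to-Bromo Swap on a Second Core

The source may hold more compounds than are shown below. What is called first, only, known or untested is meant among the compounds shown, and "the series" means these compounds.

Measured compounds:
compound 1 `O/N=C(/Nc1ccc(F)c(Cl)c1)c1ccc2occc2c1` with 5200 nM
compound 2 `O/N=C(/Nc1ccc(F)c(Br)c1)c1ccc2occc2c1` with 1600 nM
compound 3 `OCc1cc2cc(/C(=N\O)Nc3cccc(Cl)c3)ccc2o1` with 8000 nM

In an assay on isolated protein for inhibition of Indoleamine 2,3-dioxygenase 1 (Homo sapiens), read by spectrophotometry (on this read-out higher numbers stand for weaker inhibition and lower numbers for stronger inhibition), compound 1 gives 5200 nM. Compound 2 differs from it by bromo in place of chloro on an aromatic carbon and gives 1600 nM, so that a 3.3-fold lower number from compound 1 to compound 2 (0.51 log units; beyond the scatter). Compound 3, built on a different core, gives 8000 nM; the difference between the two cores is not broken down here.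

Compound 4 `OCc1cc2cc(/C(=N\O)Nc3cccc(Br)c3)ccc2o1` is not yet measured. It differs from compound 3 by bromo in place of chloro on an aromatic carbon, the same kind of change as between compound 1 and compound 2, though there the place was also ortho to a fluoro group. On the expectation that this change carries over, compound 4 is estimated at 3200 nM in this assay, somewhere between 1200 nM and 8000 nM, meaning a 2.5-fold lower number from compound 3 to compound 4 (0.40 log units; beyond the scatter), a step expected to be similar to, but less certain than, a 3.3-fold lower number from compound 1 to compound 2 (0.51 log units; beyond the scatter).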

Compound 4, half-maximal inhibitory concentration: 710 nM
Compound 4: middle estimate off by 4.5-fold (0.65 log units), on the high side; the whole stated range lies above it.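

In this assay, bromo in place of chloro again brings a lower number, with an 11-fold lower number from compound 3 to compound 4 (1.05 log units; beyond the scatter) on the core of compound 3, so the direction of the change carries over from the core of compound 1. Going by these compounds alone, only two pairs show this, and compound 1 and compound 2 also carry a fluoro group, so the data do not separate an effect of the core from one of that group. The size of the step does not carry over: the same change on two cores in this assay, a 3.3-fold lower number (0.51 log units; beyond the scatter) from compound 1 to compound 2 and an 11-fold lower number (1.05 log units; beyond the scatter) from compound 3 to compound 4, 3.5-fold (0.54 log units) apart, beyond the scatter of two such steps

Still open, as far as these compounds go, is how iodo, methyl or nitrile would read in the place of bromo on either core. Also open, from the compounds shown here alone, is whether the step would hold with an amine or a carboxylic acid in place of the hydroxymethyl group of compound 4.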